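Ring-to-chain exchange on the shared core of compound 1

This account rests on a few compounds, and the source may have more. Where it says the series, first, only, none or still open, it means among the compounds named here.

Two members of the series have numbers in an in vitro assay on 293-EBNA cells for binding affinity to corticotropin-releasing factor receptor 1 (Homo sapiens); a lower number here means a stronger inhibitor, a higher number a weaker inhibitor. Compound 1 `Cc1nc(N2CCCCC2)c2nnn(-c3ccc(C(C)C)cc3Br)c2n1` gives 46 nM and stands highest of the two; the nearest is compound 2 `CCCC(C)Nc1nc(C)nc2c1nnn2-c1c(C)cc(C)cc1C`, which in this assay gives 7.1 nM, a gap that lies beyond the usual scatter. Among the measured compounds shown here, no step between measured compounds that differ in a single place is available, so the effect of any one change on the shared core is not yet known from direct comparison.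

Compound 3 `CCC(CC)Oc1nc(C)nc2c1nnn2-c1ccc(C(C)C)cc1Br` is the next compound for this assay. It differs from compound 1 in one place: (pentan-3-yl)oxy in place of piperidin-1-yl on an aromatic carbon. Compound 2, the stronger of the two measured compounds, carries an open chain rather than a ring at the same position of its core, but nothing else in the two structures is held constant, so that comparison gives only a loose hint.

The step from compound 1 to compound 3 is expected to be a 1.8-fold lower number from compound 1 to compound 3 (0.26 log units; within the scatter), a modest move toward a lower number, and it may well stay within the scatter. For compound 3 the estimate in this assay is 25 nM, with a range from 6 nM to 100 nM.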

Compound 3, inhibition constant: 1.9 nM
Estimate against measurement, compound 3: 13-fold (1.12 log units) above; measured number below the stated range.
By their numbers in this assay, from the lowest: compound 3; then compound 2; then compound 1.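

In this assay, among the compounds shown here, (pentan-3-yl)oxy in place of piperidin-1-yl on the aromatic carbon next to the ring nitrogen gives a 24-fold lower number from compound 1 to compound 3 (1.38 log units; beyond the scatter), the first direct reading of a single change on the shared core. This position is therefore sensitive to the substituent it carries, and the large step comes with no change in the counts of heavy atoms, hydrogen-bond donors or hydrogen-bond acceptors, so those counts do not separate the two groups. No measurement at hand accounts for the size of this step.

The exchange removes the ring and replaces the attached nitrogen with oxygen at once, so the step cannot be divided between these two changes; a pentan-3-ylamino group on the core of compound 1 would separate them, since compound 2 carries an open-chain amine but differs from compound 3 in more than one place. Also open, as far as these compounds go, is whether the branched (pentan-3-yl)oxy group matters as such, which an unbranched pentyloxy chain at this position would address.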